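Hydroxamate series: cap aryl substituent exchanged

The source may hold more compounds than are shown below. What is called first, only, known or untested is meant among the compounds shown, and "the series" means these compounds.

Measured so far:
- compound 1, `O=C(CCCCC[C@H](NC(=O)C1CCCNC1=O)C(=O)Nc1ccccc1)NO`: 251 nM
- compound 2, `O=C(CCCCCCC(=O)Nc1cccc(C(F)(F)F)c1)NO`: 113 nM

In an assay on isolated protein for inhibition of histone deacetylase 8 (Homo sapiens), read by fluorescence (a higher number here means a weaker inhibitor, a lower number a stronger inhibitor), compound 2 gives 113 nM, the lower of the two numbers; compound 1 gives 251 nM, a higher number, and the gap lies beyond the usual scatter. Going by the values given here, no pair of measured compounds differs in one place only, so no measured step is available to guide the next change.

Compound 3, `Cc1cccc(NC(=O)CCCCCCC(=O)NO)c1`, is compound 2 with methyl in place of trifluoromethyl on an aromatic carbon. Among the compounds with values here, no measured step of this kind exists, so the expectation is that the step from compound 2 to compound 3 in this assay is small, either within the scatter or a modest move to a higher number. The step implied by the estimate is a 1.6-fold higher number from compound 2 to compound 3 (0.20 log units; within the scatter). Compound 3 is expected to give 180 nM, with a range from 70 nM to 450 nM.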

Compound 3, half-maximal inhibitory concentration: 523 nM
Compound 3: middle estimate off by 2.9-fold (0.46 log units), on the low side; measured number outside the range, above it.
By their numbers in this assay, from the lowest: compound 2; then compound 1; then compound 3.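

This position now has its first measured step: in this assay, methyl in place of trifluoromethyl on an aromatic carbon meta to a large group gives a 4.6-fold higher number from compound 2 to compound 3 (0.67 log units; beyond the scatter) on an otherwise unchanged structure. The step lies beyond the scatter, so the substituent at this carbon affects the reading even though neither group contains a ring or carries a net charge. No measurement at hand accounts for the size of this step.

Going by these compounds alone, with only two groups compared at this carbon, it remains open where chlorine, methoxy, nitrile or plain hydrogen would fall relative to trifluoromethyl and methyl. From the compounds shown here alone, it also remains open whether the same exchange would give a step of similar size on a longer chain or on the core of compound 1.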